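Bromo on compound 3: expected step

The compounds below may be only part of what the source reports. "The series", "measured", "known", "first", "only" and "open" are said of these compounds alone.

In a functional assay on HCT-116 cells (Homo sapiens) for inhibition, read by MTT assay, with a stated time of 72 h, in the presence of a further agent that is not named here (a higher number here means that more compound is needed for the effect, a lower number that less compound is needed), compound 1 (`CN(C)c1nc(NNC(=O)Nc2cc(Cl)nc(Cl)c2)nc2c1ccn2C`) stands at 41500 nM and compound 2 (`Cn1ccc2c(-c3ccccc3)nc(NNC(=O)Nc3cc(Cl)nc(Cl)c3)nc21`) at 660000 nM while compound 3 (`O=C(Nc1cc(Cl)nc(Cl)c1)Nc1cc2ccccn2n1`) stands at 5130 nM as the lowest of the three numbers. The gaps from compound 3 to the other two both lie beyond the scatter.

Compound 4 (`O=C(Nc1cc(Cl)nc(Cl)c1)Nc1cc2ccc(Br)cn2n1`) carries bromo in place of hydrogen on an aromatic carbon of the six-membered aromatic ring with 1 nitrogen, two atoms from the ring nitrogen (bromo in place of hydrogen on an aromatic carbon).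

Going by the values given here, only one measured step is available: a 16-fold higher number from compound 1 to compound 2 (1.20 log units; beyond the scatter) for phenyl in place of dimethylamino on an aromatic carbon. That step is large and shows that one exchange can move the number well beyond the scatter. It involves other groups on another core, however, so it gives no direction for this change. Among the compounds with values here, no measured compound shows bromo replacing hydrogen.

Within the data shown here, with no direct precedent, no shift beyond the scatter is expected in this assay and the range is kept wide on both sides. The estimated change is a 1.3-fold lower number from compound 3 to compound 4 (0.11 log units; within the scatter) and rests on the value of compound 3 as the anchor. Compound 4 is expected near 4000 nM with an estimated range from 1200 nM to 14000 nM around that middle.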

Compound 4, half-maximal effective concentration: 5260 nM
The estimate for compound 4 lay 1.3-fold (0.12 log units) below the measured number, and the stated range covers the measured number.
By their numbers in this assay, from the lowest: compounds 3 and 4 (each within the scatter of the next); then compound 1; then compound 2.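

In this assay there is a 1.0-fold higher number from compound 3 to compound 4 (0.01 log units; within the scatter) for bromo in place of hydrogen on an aromatic carbon, the only exchange shown at this position of the six-membered aromatic ring with 1 nitrogen, two atoms from the ring nitrogen. At this position, then, the hydrogen can give way to a single bromine atom with no change beyond the scatter, whereas the earlier data offered only a 16-fold higher number from compound 1 to compound 2 (1.20 log units; beyond the scatter) on another core and said nothing about this place or this exchange. The data shown give no measurement that could account for this result.

The compounds shown leave open whether an amine, a carboxylic acid or a longer chain at this same position would also stay within the scatter of compound 3, as a single bromo does. They also leave open whether bromo on another carbon of the same ring would read the same way, so the result holds for this one group at this one place and cannot yet be extended to the position in general.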